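Ring size at the substituent flanked by ring nitrogens

The compounds below may be only part of what the source reports. "The series", "measured", "known", "first", "only" and "open" are said of these compounds alone.

Compound 2 `CCCCOC(=O)NS(=O)(=O)c1ccc(CCC)cc1-c1ccc(Cn2c(CCC)nc3ccccc32)cc1` gives 14 nM in an assay on membranes from HEK293 cells for displacement of a labelled ligand from Type-2 angiotensin II receptor (Homo sapiens), read by radioligand binding; a lower number here means a stronger inhibitor, a higher number a weaker inhibitor. Among the three measured compounds it stands second highest. Going by the values given here, compound 1 `CCCCOC(=O)NS(=O)(=O)c1ccc(CCC)cc1-c1ccc(Cn2c(C3CCCC3)nc3ccccc32)cc1`, which carries cyclopentyl at the same place, gives 35 nM in this assay, and the step of a 2.5-fold lower number from compound 1 to compound 2 (0.40 log units; beyond the scatter) is the only single-point change measured so far. Compound 3 `CCCc1ccc(S(=O)(=O)NC(=O)OCCCC(F)(F)F)c(-c2ccc(Cn3c(C(C)(C)C)nc4ccccc43)cc2)c1` gives 4.5 nM in this assay; it differs from compound 2 in more than one place, so its lower number cannot be assigned to any one change.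

Compound 4 `CCCCOC(=O)NS(=O)(=O)c1ccc(CCC)cc1-c1ccc(Cn2c(C3CCC3)nc3ccccc32)cc1` is not yet measured. It differs from compound 2 by cyclobutyl in place of propyl on an aromatic carbon, on an aromatic carbon of the five-membered aromatic ring with 2 nitrogen, between two ring nitrogen atoms. Among the compounds with values here, the one step that bears on this change is a 2.5-fold lower number from compound 1 to compound 2 (0.40 log units; beyond the scatter), where propyl in place of cyclopentyl lowered the number modestly. Cyclobutyl, one four-membered non-aromatic ring of carbon only, appears in no measured compound; the series offers only the propyl and cyclopentyl points at this place. The expectation is therefore a modest rise, or none beyond the scatter, with compound 4 expected to sit nearer compound 2 than compound 1. For compound 4 the estimate is 20 nM, range 8 nM to 50 nM. This corresponds to an expected step of a 1.4-fold higher number from compound 2 to compound 4 (0.15 log units; within the scatter).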

Compound 4, inhibition constant: 12 nM
Compound 4: middle estimate off by 1.7-fold (0.22 log units), on the high side, within the range that was stated.
By their numbers in this assay, from the lowest: compound 3; then compounds 4 and 2 (each within the scatter of the next); then compound 1.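

Working notes on the substituent on the aromatic carbon between two ring nitrogen atoms: in this assay, the step of a 1.2-fold lower number from compound 2 to compound 4 (0.07 log units; within the scatter) shows that the open propyl chain and the cyclobutyl ring cannot be told apart at this place, so a ring there does not by itself separate a compound from the propyl reference. Going by these compounds alone, the step of a 2.9-fold lower number from compound 1 to compound 4 (0.46 log units; beyond the scatter) adds a distinction that the earlier compounds could not make: among the three compounds sharing this core, the higher number of compound 1 goes with cyclopentyl specifically, not with the presence of any ring, and cyclobutyl falls with propyl on the side of the lower numbers. No measurement available here explains why the two rings differ or why cyclobutyl and propyl match.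

As far as these compounds go, with only the four-membered and five-membered rings in hand, it remains open whether a smaller cyclopropyl ring would also stay with propyl and whether a larger cyclohexyl ring would extend the rise seen with cyclopentyl. From the compounds shown here alone, a longer open chain such as pentyl is equally open, as is the question of whether the rise depends on ring size or on the total count of carbon atoms at this place.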